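The compounds below may be only part of what the source reports. "The series", "measured", "known", "first", "only" and "open" are said of these compounds alone.

Compounds measured so far in a functional assay on COLO 205 cells (Homo sapiens) for inhibition, read by sulforhodamine B assay, with a stated time of 48 h; a higher number here means that more compound is tolerated, a lower number that less compound is tolerated:

Compound 1 `Nc1cc(N)c2nc(-c3ccccc3)c(Oc3ccc(Cl)c(Cl)c3)nc2c1` gives < 100000 nM in this assay; this figure is a limit of the assay and not a number.
Compound 2 `Nc1cc(N)c2nc(-c3ccccc3)c(NCc3ccc(Cl)c(Cl)c3)nc2c1` gives 66100 nM in this assay.
Compound 3 `COc1ccc(CNc2nc3cc(N)cc(N)c3nc2-c2ccccc2)cc1OC` gives < 100000 nM in this assay; this figure is a limit of the assay and not a number.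

Compound 3 therefore stands only at a limit in this assay, and a second of the three values shown is likewise a limit, as the limit of < 100000 nM in this assay, at which 2 of the 3 values shown sit, records. The one step that touches compound 3 directly is a step that the limit leaves unreadable from compound 2 to compound 3, so its size cannot be read from what is shown.

Compound 4 `Nc1cc(N)c2nc(-c3ccccc3)c(NCc3ccc(F)cc3)nc2c1` has not yet been measured in this assay. It differs from compound 3 in one place: 4-fluorophenyl in place of 3,4-dimethoxyphenyl on a saturated chain carbon bound to a nitrogen on an aromatic ring. Within the data shown here, no measured step bears on this change beyond the unreadable one, and the only number among the three values, that of compound 2, sits near the limit. The expectation for compound 4 is therefore that this assay will again report something close to the limit, and the step that the limit leaves unreadable from compound 3 to compound 4 is estimated to be no larger than the usual scatter. Compound 4 is expected to give about 70000 nM in this assay, within a range from 30000 nM to 100000 nM.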

Compound 4, concentration lethal to 50% of the cells: < 100000 nM
Compound 4: only a limit was reported; the forecaster's own chance of this, stated with the estimate: 50%; the middle value is on the limit's open side.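

In this assay, among these compounds, compound 4 gives < 100000 nM, which is a limit of the assay and not a number, so no step from compound 1, compound 2 or compound 3 to compound 4 can be read. Compound 4 thus joins the other compounds reported only as limits: the limit of < 100000 nM in this assay, at which 3 of the 4 values shown sit. The compounds shown leave open how far compound 1, compound 3 and compound 4 actually lie from that limit, and so whether 4-fluorophenyl, 3,4-dimethoxyphenyl and 3,4-dichlorophenyl differ at all in this assay.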